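Replacing the (4-chlorobenzyl)amino group of compound 3 with methoxy

The compounds below may be only part of what the source reports. "The series", "measured", "known", "first", "only" and "open" are said of these compounds alone.

In a functional assay on HEY cells (Homo sapiens) for cytotoxicity, read by MTT assay, with a stated time of 72 h (a lower number here means a stronger inhibitor, a higher number a weaker inhibitor), compound 1, `COc1cccc(CNC(=O)c2nc(Br)c3cccnc3c2N[C@H]2CC[C@H](N)CC2)c1`, gives 7000 nM. Compound 2, `C[C@H](NC(=O)c1nc(Br)c2cccnc2c1N[C@H]1CC[C@H](N)CC1)c1ccc(F)cc1`, is reported only as a limit of the assay, > 10000 nM. Compound 3, `N[C@H]1CC[C@H](Nc2c(C(=O)NCc3ccc(Cl)cc3)nc(Br)c3cccnc23)CC1`, gives 1000 nM, the lower of the two actual numbers, and its gap to compound 1 lies beyond the scatter.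

Compound 4, `COC(=O)c1nc(Br)c2cccnc2c1N[C@H]1CC[C@H](N)CC1`, carries methoxy in place of (4-chlorobenzyl)amino on a carbonyl carbon. Among the compounds with values here, no measured step removes this group altogether, so the evidence is indirect. Changes to the group on the amide-type nitrogen alone gave a 7.0-fold lower number from compound 1 to compound 3 (0.85 log units; beyond the scatter) and an at least 10-fold lower number from compound 2 to compound 3 (1.00 log units; beyond the scatter), while the remaining comparison gave an at least 1.4-fold higher number from compound 1 to compound 2 (0.15 log units; that floor lies within the scatter). Compound 1 and compound 2, with other groups at this place, both sit higher than compound 3 in this assay. Compound 4 loses the 4-chlorobenzyl group altogether, so a step of similar size towards a higher number, meaning a weaker inhibitor, is expected. The expected change is an 8.0-fold higher number from compound 3 to compound 4 (0.90 log units; beyond the scatter). For compound 4 the estimated value is 8000 nM, with an expected range of 2000 nM to 25000 nM, and the result may arrive only as a limit.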

Compound 4, half-maximal inhibitory concentration: > 20000 nM
Compound 4: no number, only a limit (the forecaster's own chance of this, stated with the estimate: 40%); middle value at least 2.5-fold (0.39 log units) from the limit.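

In this assay, within the data shown here, methoxy in place of (4-chlorobenzyl)amino on the carbonyl carbon gives an at least 20-fold higher number from compound 3 to compound 4 (1.30 log units; beyond the scatter), and methoxy in place of (3-methoxybenzyl)amino gives an at least 2.8-fold higher number from compound 1 to compound 4 (0.45 log units; beyond the scatter); the earlier compounds varied only the group on the amide-type nitrogen, whereas these steps show that removing the whole amine-linked, ring-bearing group takes compound 4 away from both compounds that gave actual numbers. Compound 2 goes against any simple link between such a group and a low number, since it keeps a ring-bearing amide group yet also gives only a limit, and the step between compound 2 and compound 4 cannot be read, both values being limits. Compound 4 is likewise reported only as a limit, so the steps to it give only a floor and its true position remains unknown: the limit of > 20000 nM in this assay, at which 1 of the 4 values shown sits.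

The compounds shown leave open whether the low number of compound 3 depends on the 4-chlorobenzyl group or on the amide-type nitrogen alone, a question that a methylamino group or a plain unsubstituted amine on the same carbonyl carbon would address. They also leave open how a carboxylic acid at this place would compare.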